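Aryl swap on the shared core, from compound 2 to compound 3

A few compounds are considered here, and "the series" means these few. Any claim that something is new, unique, unknown or untested is made for them only; others in the source may bear on it.

Measured so far:
compound 1 `O=C1Nc2ccc(Br)cc2/C1=N/NC(=S)N/N=C/c1c(F)cccc1Cl`: 1610 nM in a functional assay on HeLa cells (Homo sapiens) for inhibition, read by MTT assay; a lower number here means a stronger inhibitor, a higher number a weaker inhibitor
compound 2 `Cc1ccc2c(c1)/C(=N/NC(=S)N/N=C/c1ccccc1Br)C(=O)N2`: > 50000 nM

Compound 2 sits at the limit of > 50000 nM in this assay, at which 1 of the 2 values shown sits, of this assay, so no number is known for it. The same 2-chloro-6-fluorophenyl that compound 3 will carry is already found on compound 1, which gives 1610 nM.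

Compound 3 `Cc1ccc2c(c1)/C(=N/NC(=S)N/N=C/c1c(F)cccc1Cl)C(=O)N2` differs from compound 2 by 2-chloro-6-fluorophenyl in place of 2-bromophenyl on a carbon with a double bond to nitrogen. Among the measured compounds shown here, no measured step covers this change, so its size is open. Compound 3 is expected near 10000 nM, within 2000 nM to 50000 nM. The expected step is an at least 5.0-fold lower number from compound 2 to compound 3 (0.69 log units; beyond the scatter), a gain beyond the scatter, though the limit on compound 2 leaves it uncertain.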

Compound 3, half-maximal inhibitory concentration: 1510 nM
The estimate for compound 3 lay 6.6-fold (0.82 log units) above the measured number; measured number outside the range, below it.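

In this assay, 2-chloro-6-fluorophenyl in place of 2-bromophenyl on a carbon with a double bond to nitrogen gives an at least 33-fold lower number from compound 2 to compound 3 (1.51 log units; beyond the scatter), so the aryl group at this position has a large bearing on the read-out. This step is only a bound, as compound 2 stands at a limit of the assay: the limit of > 50000 nM in this assay, at which 1 of the 3 values shown sits.

With 2-chloro-6-fluorophenyl held constant, methyl in place of bromo on an aromatic carbon gives a 1.1-fold lower number from compound 1 to compound 3 (0.03 log units; within the scatter).

The compounds shown leave open whether chloro or fluoro alone would account for the gain. On these data alone, how an amine or a carboxylic acid on this phenyl ring would read out also remains open.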